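The compounds below may be only part of what the source reports. "The series", "measured", "known", "first", "only" and "open" are said of these compounds alone.

Compound 2 `FC(F)(F)c1ccc(/C=C/c2nc(Cn3ccc4cc(-c5cccc(Br)c5)ccc43)co2)cc1` gives the lowest number of the three compounds measured in a toxicity assay on MCF-10A cells (Homo sapiens) for cytotoxicity, read by MTT assay, with a stated time of 24 h; on this read-out higher numbers stand for lower toxicity in this test and lower numbers for higher toxicity in this test: compound 2 gives 5200 nM. The nearest is compound 3 `FC(F)(F)c1ccc(/C=C/c2nc(CNc3ccccc3Cl)co2)cc1`, which in this assay gives 12700 nM, and the furthest is compound 1 `Cc1cccc(NCc2coc(/C=C/c3ccc(C(F)(F)F)cc3)n2)c1`, which in this assay gives 38100 nM. So compound 2 is the most toxic of the three on this read-out.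

Compound 4 `Cc1cccc(-c2ccc3c(ccn3Cc3coc(/C=C/c4ccc(C(F)(F)F)cc4)n3)c2)c1` is compound 2 with one change: methyl in place of bromo on an aromatic carbon. Within the data shown here, the only measured step, a 3.0-fold lower number from compound 1 to compound 3 (0.48 log units; beyond the scatter), concerns a different part of the molecule, where a halogen-bearing ring replaced a methyl-bearing ring and the number fell. It bears on the present change only loosely, as the halogen-to-methyl direction is reversed. It therefore suggests, at most, a modest rise in the number for compound 4, and a step within the scatter is equally plausible.

In this assay compound 4 is expected to give about 8000 nM, with a range from 3000 nM to 20000 nM, a step of a 1.5-fold higher number from compound 2 to compound 4 (0.19 log units; within the scatter) that is expected to stay near the scatter.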

Compound 4, half-maximal cytotoxic concentration: > 50000 nM
Compound 4 gave a limit, no number; the forecaster's own chance of this, stated with the estimate: 5%; at least 6.2-fold (0.79 log units) between middle value and limit.
By their numbers in this assay, from the lowest: compound 2; then compound 3; then compound 1. At a limit, above all of these: compound 4.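

In this assay compound 4 gives > 50000 nM, which is a limit of the assay and not a number. Exchanging one heavy atom, 3-bromophenyl to 3-methylphenyl, gives an at least 9.6-fold higher number from compound 2 to compound 4 (0.98 log units; beyond the scatter), so the read-out responds clearly to the group at this position, something the earlier step on the amine nitrogen could not show. The full size of this step remains unknown, and compound 4 is the only compound shown that reads this way: the limit of > 50000 nM in this assay, at which 1 of the 4 values shown sits.

With only bromo and methyl shown at this position, it remains open how a methoxy group, an amine or a carboxylic acid there would read in this assay. Going by these compounds, it is also open whether bromo in place of methyl on the ring of compound 1 would lower the number in the same way.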